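Moving a ring nitrogen in a diaryl urea

The source may hold more compounds than are shown below. What is called first, only, known or untested is meant among the compounds shown, and "the series" means these compounds.

Of the compounds shown here, two have been tested in a functional assay on Bel-7402 cells (Homo sapiens) for cytotoxicity, read by MTT assay, with a stated time of 72 h; on this read-out higher numbers stand for weaker inhibition and lower numbers for stronger inhibition. Compound 1 `O=C(Nc1ccc(-n2ncc3c(Br)cccc32)cc1)Nc1ccc(Cl)c(C(F)(F)F)c1` is the shared core carrying a bromine on a carbon-only ring; in this assay compound 1 gives 1300 nM. Compound 2 `O=C(Nc1ccc(-n2ncc3cnccc32)cc1)Nc1ccc(Cl)c(C(F)(F)F)c1` replaces that ring with one that holds a nitrogen, and in this assay compound 2 gives 2700 nM, the highest of the two numbers. Among the compounds with values here, the one measured step, a 2.1-fold higher number from compound 1 to compound 2 (0.32 log units; beyond the scatter), swaps a bromine-bearing ring for a nitrogen-bearing one. Compound 3 `O=C(Nc1ccc(-n2ncc3cccnc32)cc1)Nc1ccc(Cl)c(C(F)(F)F)c1` is a different case: it keeps the same atoms as compound 2 and only relocates the nitrogen within its six-membered ring, the change being (a group of 9 heavy atoms (6 carbon, 3 nitrogen; one five-membered aromatic ring with 2 hetero atoms, one six-membered aromatic ring with 1 hetero atom) in place of a group of 9 heavy atoms (6 carbon, 3 nitrogen; one five-membered aromatic ring with 2 hetero atoms, one six-membered aromatic ring with 1 hetero atom), on an aromatic carbon). Within the data shown here, no measured step tests a relocation of this kind, so a step beyond the scatter is not expected, and the estimated 1.1-fold lower number from compound 2 to compound 3 (0.03 log units; within the scatter) reflects that. Compound 3 is therefore expected to give about 2500 nM, within a range from 1000 nM to 6500 nM.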

Compound 3, half-maximal inhibitory concentration: 20900 nM
For compound 3 the middle estimate is 8.4-fold (0.92 log units) below the measured one, and the stated range ends below it.
By their numbers in this assay, from the lowest: compound 1; then compound 2; then compound 3.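

Where the nitrogen sits in the six-membered ring clearly matters in this assay: with no atom gained or lost, relocating it gives a 7.7-fold higher number from compound 2 to compound 3 (0.89 log units; beyond the scatter). This step is larger than the one seen when the bromine-bearing ring gave way to a nitrogen-bearing ring, and measured against the bromine compound the change reaches a 16-fold higher number from compound 1 to compound 3 (1.21 log units; beyond the scatter). Nothing available here explains why moving a single ring atom has so large an effect.

Only two placements of the nitrogen are shown, so the other places in that ring remain open, as does the outcome of pairing a ring nitrogen with a bromine. On these data alone, it is also open whether an amine or a methoxy group on the ring of compound 3 would bring the number back down.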